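A few compounds are considered here, and "the series" means these few. Any claim that something is new, unique, unknown or untested is made for them only; others in the source may bear on it.

Measured so far in a functional assay on A549 cells (Homo sapiens) for antiproliferative activity, with a stated time of 5 days; on this read-out lower numbers stand for stronger inhibition and higher numbers for weaker inhibition:

- Compound 1 `CC1OC2(C=CC(=O)C=C2)N(c2nc(-c3ccc4ccccc4c3)nn2-c2ccc3ccccc3c2)C1=O`: 300 nM
- Compound 2 `O=C1C=CC2(C=C1)OCC(=O)N2c1nc(-c2ccc3ncccc3c2)nn1-c1ccccc1`: 170 nM
- Compound 3 `CC1OC2(C=CC(=O)C=C2)N(c2nc(-c3cccc4ccccc34)nn2-c2ccccc2)C1=O`: 180 nM

Compound 2 gives 170 nM, and the other two values lie within the usual scatter of that number, so the three compounds cannot be ranked on these data. Compound 2 therefore stands level with the others and makes a fair starting point.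

The next compound is compound 4 `O=C1C=CC2(C=C1)OCC(=O)N2c1nc(-c2ccc(F)c3ccccc23)nn1-c1ccccc1`, which has not yet been measured. It differs from compound 2 in one place: 4-fluoronaphthalen-1-yl in place of quinolin-6-yl on an aromatic carbon. In words, 4-fluoronaphthalen-1-yl takes the place of quinolin-6-yl on an aromatic carbon of a five-membered aromatic ring with 3 nitrogen, between two ring nitrogen atoms.

Among the measured compounds shown here, no pair of measured compounds differs in only one place, so no direct comparison exists for this change. Still, compound 1 at 300 nM and compound 3 at 180 nM carry other groups on that carbon, and both stay within the scatter of compound 2. A change beyond the scatter is therefore not expected, and no direction can be favoured with confidence.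

The estimated step of a 1.2-fold higher number from compound 2 to compound 4 (0.07 log units; within the scatter) is small. For compound 4 the expected value is 200 nM, with an estimated range of 80 nM to 500 nM.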

Compound 4, half-maximal inhibitory concentration: 320 nM
Estimate against measurement, compound 4: 1.6-fold (0.20 log units) below; low and high end bracket the measured number.
By their numbers in this assay, from the lowest: compounds 2, 3, 1 and 4 (each within the scatter of the next).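

Among the compounds shown here, this pair is the first to differ in only one place, giving a direct reading in this assay at the aromatic carbon of the five-membered aromatic ring with 3 nitrogen. Replacing quinolin-6-yl with 4-fluoronaphthalen-1-yl gives a 1.9-fold higher number from compound 2 to compound 4 (0.27 log units; within the scatter) and so does not separate the two groups. This exchange removes a ring nitrogen and a hydrogen-bond acceptor and adds a fluorine, yet this single pair shows no clear effect of the whole exchange, and no measurement shown here offers an explanation for the result.

Going by these compounds, both groups in this pair contain two six-membered aromatic rings, so it remains open whether the number would hold with something quite different on this carbon, such as an amine or a carboxylic acid. Because the exchange alters the ring atoms and adds fluorine at once, this pair also cannot assign any part of the small difference to either alteration alone.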